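This account rests on a few compounds, and the source may have more. Where it says the series, first, only, none or still open, it means among the compounds named here.

In a functional assay on A549 cells (Homo sapiens) for antiproliferative activity, read by MTT assay, with a stated time of 72 h (on this read-out lower numbers stand for stronger inhibition and higher numbers for weaker inhibition), compound 1 `NC1CCc2nc(-c3ccncc3)nc(Nc3cccc(F)c3)c2C1` gives 19400 nM and compound 2 `N[C@@H]1CCc2nc(-c3ccncc3)nc(Nc3cccc(F)c3)c2C1` gives 17800 nM, so compound 2 stands level with compound 1. Compound 3 `N[C@H]1CCc2nc(-c3ccncc3)nc(Nc3cccc(F)c3)c2C1` differs from compound 2 only in how one centre is drawn: the two compounds have the same atoms and bonds and differ only in configuration as drawn: 1 of 1 stereo elements differ; a stereocentre at a saturated ring carbon is drawn R in compound 2 and S in compound 3. Within the data shown here, the one measured step that bears on this is a 1.1-fold lower number from compound 1 to compound 2 (0.04 log units; within the scatter), and it concerns that same centre, as the fact that one of compounds 1 and 2 is drawn with a defined configuration and the other without, at the place where they differ shows. Since that step stays within the scatter, no change beyond the scatter is expected in this assay. The expected step is a 1.1-fold higher number from compound 2 to compound 3 (0.05 log units; within the scatter). Compound 3 is estimated at 20000 nM, with an expected range from 9000 nM to 45000 nM.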

Compound 3, half-maximal inhibitory concentration: 23300 nM
Compound 3: the middle estimate sits 1.2-fold (0.07 log units) below what was measured, and the stated range covers the measured number.
By their numbers in this assay, from the lowest: compounds 2, 1 and 3 (each within the scatter of the next).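

In this assay, the two defined configurations at the saturated ring carbon can now be compared directly, and the change from R to S gives a 1.3-fold higher number from compound 2 to compound 3 (0.12 log units; within the scatter). The S form, set against the form drawn without a configuration, gives a 1.2-fold higher number from compound 1 to compound 3 (0.08 log units; within the scatter). Neither defined form separates from the undefined one, and the R and S comparison isolates a single change: the fact that compounds 2 and 3 differ only in the configuration as drawn

As far as these compounds go, whether this centre would matter with another group on it stays open. An amide or a hydroxyl group at that carbon, or a longer chain carrying the amine, could give a different result.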